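Aryl swap on the shared core: benzoxazole for tert-butylpyrazole

The source may hold more compounds than are shown below. What is called first, only, known or untested is meant among the compounds shown, and "the series" means these compounds.

Compound 1 `CC(C)(C)n1cc(-c2cc(C(O)(C(F)(F)F)C(F)(F)F)cnc2N2CCN(S(=O)(=O)c3ccc(N)nc3)CC2)cn1` gives the higher of the two numbers recorded in an ADME assay (liver) for metabolic stability, with Liver microsome (Rattus norvegicus) as the target, using microsomes and NADPH, with a stated time of 30 min, tested at 1 uM (on this read-out higher numbers stand for fast clearance and lower numbers for slow clearance), at 459 mL.min-1.g-1. Compound 2 `COc1ccc(-c2cc(C(O)(C(F)(F)F)C(F)(F)F)cnc2N2CCN(S(=O)(=O)c3ccc(N)nc3)CC2)cn1`, in which the same position carries a 6-methoxypyridin-3-yl group, gives 265 mL.min-1.g-1 in this assay; the step of a 1.7-fold lower number from compound 1 to compound 2 (0.24 log units; within the scatter) is the only one measured at this position.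

Compound 3 `Nc1ccc(S(=O)(=O)N2CCN(c3ncc(C(O)(C(F)(F)F)C(F)(F)F)cc3-c3ccc4ocnc4c3)CC2)cn1` is not yet measured. It differs from compound 1 by 1,3-benzoxazol-5-yl in place of 1-(tert-butyl)-1H-pyrazol-4-yl on an aromatic carbon. Going by the values given here, the one step that bears on this position, from compound 1 to compound 2, stayed within the scatter, so a change of a different kind at the same site offers no ground to expect more than a step of that order in this assay for compound 3, in either direction. The estimate for compound 3 is therefore 350 mL.min-1.g-1, with a range of 170 mL.min-1.g-1 to 700 mL.min-1.g-1, corresponding to an expected step of a 1.3-fold lower number from compound 1 to compound 3 (0.12 log units; within the scatter).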

Compound 3, intrinsic clearance in microsomes: 120 mL.min-1.g-1
Compound 3: the middle estimate sits 2.9-fold (0.46 log units) above what was measured, outside the stated range (below it).
By their numbers in this assay, from the lowest: compound 3; then compounds 2 and 1 (each within the scatter of the next).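

In this assay, 1,3-benzoxazol-5-yl in place of 1-(tert-butyl)-1H-pyrazol-4-yl gives a 3.8-fold lower number from compound 1 to compound 3 (0.58 log units; beyond the scatter), and in place of 6-methoxypyridin-3-yl it gives a 2.2-fold lower number from compound 2 to compound 3 (0.34 log units; beyond the scatter), so this position can carry a change beyond the scatter, which the earlier step, a 1.7-fold lower number from compound 1 to compound 2 (0.24 log units; within the scatter), did not show. The leaving and entering groups match in heavy atoms, hydrogen-bond donors and hydrogen-bond acceptors as counted, so these counts do not separate compound 1 from compound 3; the entering group differs in its added six-membered aromatic ring of carbon only and its oxygen. Nothing available here accounts for the lower number.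

Which part of 1,3-benzoxazol-5-yl goes with the lower number stays open. A plain phenyl ring, or a saturated amine such as morpholine, at this position could help to settle that.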